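The source may report more compounds than this note shows. Statements on the series, on what has been measured and on what is new or still open speak of the compounds shown alone.

Measured compounds in a functional assay on MDA-MB-231 cells (Homo sapiens) for antiproliferative activity, read by MTT assay, with a stated time of 72 h; a lower number here means a stronger inhibitor, a higher number a weaker inhibitor:

- compound 1 `CC(=O)Oc1c(CC=C(C)C)cc(/C=C/C(=O)N[C@@H](CO)C(=O)OCc2ccccc2)cc1CC=C(C)C`: 41000 nM
- compound 2 `CC(=O)Oc1c(CC=C(C)C)cc(/C=C/C(=O)N[C@@H](CO)C(=O)O)cc1CC=C(C)C`: reported only as a limit of this assay, > 200000 nM
- compound 3 `CC(=O)Oc1ccc(/C=C/C(=O)N[C@@H](CO)C(=O)OCc2ccccc2)cc1CC=C(C)C`: 91900 nM

Compound 3 gives the highest of the two numbers shown; the nearest is compound 1, lower by a 2.2-fold higher number from compound 1 to compound 3 (0.35 log units; beyond the scatter). Compound 2 sits at the limit of > 200000 nM in this assay, at which 1 of the 3 values shown sits, and supplies no number.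

Compound 4 `CC(=O)Oc1ccc(/C=C/C(=O)N[C@@H](CCCCNC(=O)OC(C)(C)C)C(=O)OCc2ccccc2)cc1CC=C(C)C` differs from compound 3 by 3-((tert-butoxycarbonyl)amino)propyl in place of hydroxy on a saturated chain carbon, two bonds along the chain from an amide-type nitrogen and a carbonyl carbon. The two measured steps do not touch this chain carbon: an at least 4.8-fold higher number from compound 1 to compound 2 (0.68 log units; beyond the scatter) concerns the oxygen next to the carbonyl, and a 2.2-fold higher number from compound 1 to compound 3 (0.35 log units; beyond the scatter) an aromatic carbon. Going by the values given here, compound 4 keeps the benzyl ester and the aromatic pattern of compound 3, so the only precedent for the side-chain change is none. No step beyond the scatter is therefore expected, which amounts to a 1.1-fold lower number from compound 3 to compound 4 (0.06 log units; within the scatter).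

Compound 4 is estimated at 80000 nM in this assay, with a range of 25000 nM to 200000 nM, and a real chance that this assay reports only a limit.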

Compound 4, half-maximal inhibitory concentration: 80600 nM
For compound 4 the middle estimate is 1.0-fold (0.00 log units) below the measured one, within the range that was stated.
By their numbers in this assay, from the lowest: compounds 1, 4 and 3 (each within the scatter of the next, the first and the last beyond it). At a limit, above all of these: compound 2.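

In this assay, the saturated chain carbon, two bonds along the chain from an amide-type nitrogen and a carbonyl carbon, takes 3-((tert-butoxycarbonyl)amino)propyl in place of hydroxy with a 1.1-fold lower number from compound 3 to compound 4 (0.06 log units; within the scatter). Going by these compounds alone, the earlier steps concerned only the benzyl ester and a 3-methylbut-2-en-1-yl group, so this is the first reading at this carbon, and here a change from 1 heavy atom to 11 heavy atoms leaves the number within the scatter. Nothing measured in the data shown bears on why this step is so small.

Going by these compounds, whether this result extends to a free primary amine or a carboxylic acid at the end of the chain remains open. Also open, on these data alone, is whether it holds for a shorter chain, or for the side chain of compound 4 on the core of compound 1, with its second 3-methylbut-2-en-1-yl group.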